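The source may hold more compounds than are shown below. What is called first, only, known or untested is meant among the compounds shown, and "the series" means these compounds.

Compound 1 `CC(C)=CCOc1ccc(C(=O)/C=C/c2ccncc2)c(O)c1` and compound 2 `CC(C)=CCOc1ccc(C(=O)/C=C/c2cccnc2)c(O)c1` share one core and differ only in the pyridyl attachment. Among the compounds with values here, in an ADME assay on Vero cells (Chlorocebus sabaeus) for cytotoxicity, read by resazurin assay, with a stated time of 72 h (on this read-out higher numbers stand for lower toxicity in this test and lower numbers for higher toxicity in this test), compound 1 gives 40000 nM and compound 2 gives 210000 nM; the single step on record, a 5.3-fold higher number from compound 1 to compound 2 (0.72 log units; beyond the scatter), concerns pyridin-3-yl in place of pyridin-4-yl. Among the two numbers compound 1 stands lowest, the nearest being compound 2.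

Compound 3 `COc1cc(OCC=C(C)C)ccc1C(=O)/C=C/c1ccncc1` is not yet measured. It differs from compound 1 by methyl in place of hydrogen on an oxygen on an aromatic ring; read one bond further out, the change is hydroxy to methoxy. Within the data shown here, no measured step touches this oxygen, so the pyridyl step gives no guidance on its size or direction, and there is nothing to suggest a move beyond the scatter. Compound 3 is therefore expected to stay close to compound 1, a step of no change at the digits printed from compound 1 to compound 3 (within the scatter). The estimate for compound 3 in this assay is 40000 nM, within 15000 nM to 110000 nM.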

Compound 3, half-maximal cytotoxic concentration: 16000 nM
Compound 3: middle estimate off by 2.5-fold (0.40 log units), on the high side, and the stated range covers the measured number.
By their numbers in this assay, from the lowest: compound 3; then compound 1; then compound 2.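

In this assay the oxygen on an aromatic ring proves to be a place that responds, with methyl in place of hydrogen giving a 2.5-fold lower number from compound 1 to compound 3 (0.40 log units; beyond the scatter) and so moving the number toward higher toxicity in this test. Within the data shown here, the pyridyl change gave a 5.3-fold higher number from compound 1 to compound 2 (0.72 log units; beyond the scatter) in the other direction, so the core of compound 1 now has two places where a single change moves the number beyond the scatter, though with only one step at each place neither shows a trend. Nothing measured here bears on the reason for the hydroxy to methoxy step.

On these data alone, whether a longer chain on this oxygen, such as ethoxy or propoxy, would extend the step or reverse it remains open. Also open, as far as these compounds go, is whether hydroxy to methoxy would act the same way with the pyridin-3-yl group of compound 2 in place of pyridin-4-yl.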